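Allyl for isopropyl on the carbamate nitrogen

This account rests on a few compounds, and the source may have more. Where it says the series, first, only, none or still open, it means among the compounds named here.

Three carbamates built on one shared core have been measured in a functional assay on MOLT-4F cells (Homo sapiens) for inhibition; a lower number here means a stronger inhibitor, a higher number a weaker inhibitor. Compound 1 `CCCCNC(=O)OC/C=C(\C)C1=CC(=O)C(C)(C)O1` gives 5.3 ug/mL there. Compound 3 `C/C(=C\COC(=O)NC(C)C)C1=CC(=O)C(C)(C)O1` gives 6.6 ug/mL in this assay, the higher of the two numbers on record, though the step of a 1.2-fold higher number from compound 1 to compound 3 (0.10 log units; within the scatter) means the two stand together. Compound 2 `C/C(=C\COC(=O)Nc1ccccc1)C1=CC(=O)C(C)(C)O1` reaches only > 200 ug/mL in this assay, which is a limit of the assay and not a number; the record shows (the limit of > 200 ug/mL in this assay, at which 1 of the 3 values shown sits). The step of an at least 37-fold higher number from compound 1 to compound 2 (1.57 log units; beyond the scatter) and the step of an at least 30-fold lower number from compound 2 to compound 3 (1.48 log units; beyond the scatter) both separate the phenyl carbamate from the two alkyl carbamates.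

Compound 4 `C=CCNC(=O)OC/C=C(\C)C1=CC(=O)C(C)(C)O1` has not been measured. It differs from compound 3 by allyl in place of isopropyl on an amide-type nitrogen. The step that bears on it most closely is a 1.2-fold higher number from compound 1 to compound 3 (0.10 log units; within the scatter), where one small alkyl group replaced another and the numbers stayed together; the large steps involving compound 2 concern a phenyl group and do not apply. Compound 4 is therefore expected to stay with the alkyl carbamates, with an estimated step of a 1.1-fold lower number from compound 3 to compound 4 (0.04 log units; within the scatter). Compound 4 is estimated at 6 ug/mL in this assay, expected between 3 ug/mL and 13 ug/mL.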

Compound 4, half-maximal inhibitory concentration: 7.7 ug/mL
Compound 4: the middle estimate sits 1.3-fold (0.11 log units) below what was measured; the range from low to high includes it.
By their numbers in this assay, from the lowest: compounds 1, 3 and 4 (each within the scatter of the next). At a limit, above all of these: compound 2.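

In this assay, a double bond in the group on the amide-type nitrogen keeps the compound with the saturated alkyl carbamates, with a 1.2-fold higher number from compound 3 to compound 4 (0.07 log units; within the scatter) and a 1.5-fold higher number from compound 1 to compound 4 (0.16 log units; within the scatter), so this position accepts allyl as it accepts butyl and isopropyl. Among the groups shown, only phenyl goes against this, with an at least 25-fold lower number from compound 2 to compound 4 (1.41 log units; beyond the scatter), which shows that one double bond in an open chain is not enough to produce the gap seen with the phenyl carbamate. Compound 2 is held at a limit of the assay and not at a number: the limit of > 200 ug/mL in this assay, at which 1 of the 4 values shown sits.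

From the compounds shown here alone, it remains open whether benzyl or a chain ending in a carboxylic acid or an amine on this nitrogen would stay with the alkyl carbamates or fall towards compound 2. Going by these compounds, how far a chain longer than butyl would hold is also open.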